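A few compounds are considered here, and "the series" means these few. Any claim that something is new, unique, unknown or untested is made for them only; others in the source may bear on it.

Compounds measured so far:
Compound 1, `CCCCNC(=O)[C@@H](NC(=O)c1cccc(Cn2ccnc2)c1)[C@@H](C)CC`: in an assay on HEK293 cells for displacement of a labelled ligand from Type-2 angiotensin II receptor (Homo sapiens), tested at 10 uM (a lower number here means a weaker effect, a higher number a stronger effect of the compound at the concentration tested), compound 1 gives 3%.
Compound 2, `CC[C@H](C)[C@H](NC(=O)c1cccc(Cn2ccnc2)c1)c1nn[nH]n1`: in this assay compound 2 gives "not active" (no number reported).
Compound 3, `CCCCS(=O)(=O)NC(=O)[C@@H](NC(=O)c1cccc(Cn2ccnc2)c1)[C@@H](C)CC`: in this assay compound 3 gives "not determined" (no result reported).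

All three compounds share the same core; they differ only in the group carried on the amide-type nitrogen at one end. On the numbers shown, compound 3 has no single value of its own, and it is not alone in this: compound 2 is recorded without a number as well. Going by the values given here, the only number in the set belongs to compound 1, which is close to nothing. Compound 4, `CC[C@H](C)[C@H](NC(=O)c1cccc(Cn2ccnc2)c1)C(=O)NNS(=O)(=O)c1ccc(C)cc1`, carries a change at the same position as compound 3: ((4-methylphenyl)sulfonyl)amino in place of butylsulfonyl on an amide-type nitrogen. Among the compounds with values here, since no measured pair differs in one place, no step is known to compare against. Given that compound 1 gives 3% and compound 2 gives "not active" (no number reported), no step beyond the usual scatter is expected for compound 4 in this assay. For compound 4 the estimate in this assay is 5%, expected to lie between 0% and 20%.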

Compound 4, a percentage reported as inhibition, at one concentration (the size of the read-out at that concentration, not a potency): 20%
Compound 4: the middle estimate sits 15 percentage points below what was measured, within the range that was stated.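

In this assay, putting ((4-methylphenyl)sulfonyl)amino in place of butyl on an amide-type nitrogen gives a number 17 percentage points higher from compound 1 to compound 4 (beyond the scatter). Going by these compounds alone, this is the first sign that the group at this position can move the read-out at all, although the read-out comes from a single concentration and says nothing about potency. The step from compound 3 to compound 4 cannot be read, as compound 3 has no result, and no measurement shown accounts for the change seen with compound 4.

The change from butyl brings in several features at once, a sulfonyl, an extra nitrogen and a six-membered aromatic ring, and the compounds shown do not separate what each contributes. On these data alone, it also remains open how the read-out would respond to a carboxylic acid at this position, or to a plain phenyl in place of the 4-methylphenyl group.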